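Lipophilicity notes: compound 3 to compound 4

The compounds below may be only part of what the source reports. "The series", "measured", "known", "first", "only" and "open" are said of these compounds alone.

Of the compounds shown here, three have been measured in a physicochemical assay for lipophilicity, at pH 7.4; on this read-out lower numbers stand for lower lipophilicity and higher numbers for higher lipophilicity. In this assay compound 1 `O=C(Cc1nn(C2CCNC2)c(=O)c2ccccc12)Nc1ccc(OC(F)(F)F)c(Cl)c1` gives 3.03, compound 2 `O=C(O)Cn1nc(Cc2nc3cc(Cl)c(OCC(F)F)cc3[nH]2)c2ccccc2c1=O` gives 1.97, and compound 3 `C[C@@H](C(=O)O)c1nn(Cc2cn3cc(OCC4CC4)c(Cl)cc3n2)c2ccccc2c1=O` gives 2.41. Compound 3 stands second highest of the three: its nearest neighbour is compound 2, lower by a margin beyond the scatter, while compound 1 lies higher, also beyond the scatter.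

Compound 4 `CC(C)(C(=O)O)c1nn(Cc2cn3cc(OCC4CC4)c(Cl)cc3n2)c2ccccc2c1=O` differs from compound 3 in one place: 1-carboxy-1-methylethyl in place of 1-carboxyethyl on an aromatic carbon. Going by the values given here, no measured pair in the set shows this change, so the step must be judged from the change alone. A modest rise in this assay is expected, probably just beyond the scatter. The estimated step is a number 0.34 log units higher from compound 3 to compound 4 (beyond the scatter). Compound 4 is expected to give 2.75, within a range from 2.35 to 3.15.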

Compound 4, distribution coefficient: 2.95
For compound 4 the middle estimate is 0.20 log units below the measured one, and the stated range covers the measured number.
By their numbers in this assay, from the lowest: compound 2; then compound 3; then compounds 4 and 1 (each within the scatter of the next).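

In this assay, going by these compounds alone, the only single-change pair gives a step of a number 0.54 log units higher from compound 3 to compound 4 (beyond the scatter), with 1-carboxy-1-methylethyl in place of 1-carboxyethyl on an aromatic carbon. The entering group has one more carbon and no defined stereocentre, while the carboxylic acid stays and the rest of the compound is unchanged. Nothing at hand accounts for the size of this step.

Still open, going by these compounds, is how a longer chain at this carbon, such as ethyl in place of the added methyl, or a cyclopropyl ring closed on it, would read. On these data alone, the opposite stereoisomer of the 1-carboxyethyl group also remains open.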